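The source may report more compounds than this note shows. Statements on the series, on what has been measured and on what is new or still open speak of the compounds shown alone.

Measured in a functional assay on A-375 cells (Homo sapiens) for activation, with a stated time of 3 days; on this read-out lower numbers stand for an effect already at smaller amounts and higher numbers for an effect only at larger amounts of compound:
Compound 1 `O=C(Nc1ccc(-c2c[nH]cn2)cc1)C1CCCN(Cc2ccc(F)c(F)c2)C1`: 16000 nM
Compound 2 `O=C(Nc1ccc(-c2ncc[nH]2)cc1)C1CCCN(Cc2ccc(F)c(F)c2)C1`: 8000 nM
Compound 3 `O=C(Nc1ccc(-c2ccn[nH]2)cc1)C1CCCN(Cc2ccc(F)c(F)c2)C1`: 580 nM

Compound 3, at 580 nM, has the lowest number of the three. Compound 4 `O=C(Nc1ccc(-c2ccoc2)cc1)C1CCCN(Cc2ccc(F)c(F)c2)C1` has furan-3-yl in place of 1H-pyrazol-5-yl on an aromatic carbon. The measured steps at this same place are a 28-fold lower number from compound 1 to compound 3 (1.44 log units; beyond the scatter) and a 14-fold lower number from compound 2 to compound 3 (1.14 log units; beyond the scatter), both large, and a 2.0-fold lower number from compound 1 to compound 2 (0.30 log units; within the scatter), which is small. Going by the values given here, exchanging this group can therefore shift this assay strongly, although no furan-3-yl compound has been measured. Both other groups tried here gave higher numbers than compound 3, so a moderate rise is expected, with much uncertainty. The expected change is a 2.6-fold higher number from compound 3 to compound 4 (0.41 log units; beyond the scatter). Compound 4 is estimated at 1500 nM, with an expected range from 250 nM to 9000 nM.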

Compound 4, half-maximal effective concentration: 3000 nM
The estimate for compound 4 lay 2.0-fold (0.30 log units) below the measured number; low and high end bracket the measured number.
By their numbers in this assay, from the lowest: compound 3; then compound 4; then compounds 2 and 1 (each within the scatter of the next).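

Furan-3-yl, with 0 hydrogen-bond donors, does not end up last in the series: the step is a 2.7-fold lower number from compound 2 to compound 4 (0.43 log units; beyond the scatter) and a 5.3-fold lower number from compound 1 to compound 4 (0.73 log units; beyond the scatter), so it beats both imidazole groups. It still falls short of 1H-pyrazol-5-yl, with a 5.2-fold higher number from compound 3 to compound 4 (0.71 log units; beyond the scatter). Donor count alone therefore does not set the order among these five-membered aromatic rings.

Nothing available here explains why these groups differ. Also open, as far as these compounds go, is how a six-membered phenyl ring or a simple amine would compare on this same aromatic carbon.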